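A Urea-to-Benzamide Swap at the Acyl Terminus

A few compounds are considered here, and "the series" means these few. Any claim that something is new, unique, unknown or untested is made for them only; others in the source may bear on it.

Compound 3 `CC(C)[C@@H](NC(=O)NCc1ccccc1)C(=O)N1CCC(c2ccc(Cl)cc2)CC1` carries the highest number among the three measured compounds in an assay on THP-1 cells for displacement of a labelled ligand from C-C chemokine receptor type 1 (Homo sapiens) (a lower number here means a stronger inhibitor, a higher number a weaker inhibitor), giving 180 nM. Compound 1 `CC(C)CC(=O)N[C@@H](C(=O)N1CCC(c2ccc(Cl)cc2)CC1)C(C)C` gives 32 nM in this assay, and compound 2 `Cc1ccc(CCC(=O)N[C@@H](C(=O)N2CCC(c3ccc(Cl)cc3)CC2)C(C)C)cc1` gives 105 nM. The step of a 5.6-fold higher number from compound 1 to compound 3 (0.75 log units; beyond the scatter) lies beyond the scatter, whereas a 1.7-fold higher number from compound 2 to compound 3 (0.23 log units; within the scatter) does not, so compound 3 and compound 2 cannot be told apart on these numbers.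

Compound 4 `CC(C)[C@@H](NC(=O)c1ccc(F)c(F)c1)C(=O)N1CCC(c2ccc(Cl)cc2)CC1` differs from compound 3 by 3,4-difluorophenyl in place of benzylamino on a carbonyl carbon. Going by the values given here, no measured compound carries an aromatic ring directly on this carbonyl carbon, so the nearest guidance comes from the two steps in which benzylamino entered at the same place, a 5.6-fold higher number from compound 1 to compound 3 (0.75 log units; beyond the scatter) and a 1.7-fold higher number from compound 2 to compound 3 (0.23 log units; within the scatter). Reversing that direction, and given that compound 1 gives 32 nM, a modest move toward a lower number is expected, though an aryl group bound to the carbonyl carbon itself has no precedent here, so the range is kept wide. Compound 4 is estimated at 80 nM with a range of 25 nM to 250 nM, corresponding to an expected step of a 2.3-fold lower number from compound 3 to compound 4 (0.35 log units; beyond the scatter).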

Compound 4, half-maximal inhibitory concentration: 14 nM
For compound 4 the middle estimate is 5.7-fold (0.76 log units) above the measured one, outside the stated range (below it).
By their numbers in this assay, from the lowest: compound 4; then compound 1; then compounds 2 and 3 (each within the scatter of the next).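

With 3,4-difluorophenyl on the carbonyl carbon, this position gives the strongest inhibitor of the four in this assay, which shows that an aromatic ring can be carried here: in place of benzylamino the change gives a 13-fold lower number from compound 3 to compound 4 (1.11 log units; beyond the scatter), and in place of 2-(4-methylphenyl)ethyl it gives a 7.5-fold lower number from compound 2 to compound 4 (0.88 log units; beyond the scatter). The group also surpasses isobutyl, with a 2.3-fold lower number from compound 1 to compound 4 (0.36 log units; beyond the scatter), so the earlier picture, in which both ring-bearing groups gave higher numbers than isobutyl, does not hold for a ring bound directly to the carbonyl carbon. Nothing available explains the size of these steps.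

Whether the ring itself or its two fluorines account for the gain remains open. A plain phenyl group on the same carbonyl carbon would separate the two.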